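This account rests on a few compounds, and the source may have more. Where it says the series, first, only, none or still open, it means among the compounds named here.

Working notes on the series. Two members have been tested in a functional assay on SK-OV-3 cells (Homo sapiens) for inhibition, read by MTT assay, with a stated time of 24 h (a higher number here means a weaker inhibitor, a lower number a stronger inhibitor), so far, and both come back without a number. Compound 1, `C/C=C(\C)C(=O)O[C@H]1[C@]2(C)C[C@@H]3O[C@@]1(O)C=C1C4=CC(=O)O[C@@H](c5ccoc5)[C@]4(C)CC[C@@H]1[C@]3(C)[C@@H]2[C@@H](O)C(=O)OC`, carries a tiglate ester at one end of the shared core and a methyl ester on the side chain. In this assay compound 1 reaches only the limit of the assay at > 100000 nM. Compound 2, `CCOC(=O)[C@H](O)[C@@H]1[C@@]2(C)C[C@@H]3O[C@@](O)(C=C4C5=CC(=O)O[C@@H](c6ccoc6)[C@]5(C)CC[C@@H]4[C@@]31C)[C@H]2O`, has the free hydroxyl in place of the tiglate ester and an ethyl ester on the side chain. In this assay compound 2 also sits at the limit of the assay, > 100000 nM. Compound 2 therefore stands at the limit, and the limit of > 100000 nM in this assay, at which 2 of the 2 values shown sit, describes where the whole set stands.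

The next member, compound 3, `COC(=O)[C@H](O)[C@@H]1[C@@]2(C)C[C@@H]3O[C@@](O)(C=C4C5=CC(=O)O[C@@H](c6ccoc6)[C@]5(C)CC[C@@H]4[C@@]31C)[C@H]2O`, differs from compound 2 only at the side-chain ester: hydrogen in place of methyl on a saturated chain carbon bound to an oxygen next to a carbonyl group. For the measured compounds named here, no step between measured compounds is available for this change. Since compound 2 gives only the limit > 100000 nM, the step from compound 2 to compound 3 is expected to be no larger than the scatter, a step that the limit leaves unreadable from compound 2 to compound 3. For compound 3 the value in this assay is estimated at 150000 nM, within 70000 nM to 400000 nM, most likely reported again as a limit.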

Compound 3, half-maximal inhibitory concentration: > 100000 nM
Compound 3 was reported as a limit; the forecaster's own chance of this, stated with the estimate: 85%; the middle value is on the limit's open side.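

In this assay compound 3 gives > 100000 nM, a limit of the assay and not a number. For the compounds shown here, no step from compound 1 or compound 2 to compound 3 can be read. The compounds shown leave open whether ethyl to methyl on the side-chain ester, or loss of the tiglate ester, changes inhibition at all, with the set resting on one value: the limit of > 100000 nM in this assay, at which 3 of the 3 values shown sit.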